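Exchanging Hydroxy for Nitro on the Aromatic Ring

The compounds below may be only part of what the source reports. "The series", "measured", "known", "first", "only" and "open" are said of these compounds alone.

Of the compounds shown here, three built on one shared core have been tested in a functional assay on OVCAR-3 cells (Homo sapiens) for inhibition, read by sulforhodamine B assay, with a stated time of 48 h; a higher number here means a weaker inhibitor of growth, a lower number a stronger inhibitor of growth. Compound 1 `CC1=CC[C@H](C(C)(C)NC(=S)N/N=C/c2ccccc2)CC1` carries a bare aromatic ring at the end of the chain and gives 8700 nM. Compound 2 `CC1=CC[C@H](C(C)(C)NC(=S)N/N=C/c2ccccc2O)CC1` adds a hydroxy to that ring and gives 5500 nM. Compound 3 `CC1=CC[C@H](C(C)(C)NC(=S)N/N=C/c2cccc(Cl)c2)CC1` carries a chloro instead and gives 13600 nM. Compound 2 has the lowest number of the three, but the step of a 1.6-fold lower number from compound 1 to compound 2 (0.20 log units; within the scatter) is too small to rank it against compound 1, while the step of a 2.5-fold higher number from compound 2 to compound 3 (0.39 log units; beyond the scatter) does set it apart from compound 3.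

Compound 4 `CC1=CC[C@H](C(C)(C)NC(=S)N/N=C/c2ccccc2[N+](=O)[O-])CC1` is the next variation: nitro in place of hydroxy on an aromatic carbon. Among the compounds with values here, two measured steps bear on this. The step of a 1.6-fold lower number from compound 1 to compound 2 (0.20 log units; within the scatter) shows that placing a hydroxy on the ring barely moved the number, and the step of a 1.6-fold higher number from compound 1 to compound 3 (0.19 log units; within the scatter) shows that a chloro on the ring also stayed within the scatter. Within the data shown here, no measured compound carries a nitro, so the direction of this change is not anchored. The expectation is therefore a small shift, if any, leaning toward a slightly higher number: the step of a 1.5-fold higher number from compound 2 to compound 4 (0.16 log units; within the scatter) is estimated. Compound 4 is expected to give about 8000 nM in this assay, within a range of 3000 nM to 22000 nM.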

Compound 4, concentration for 50% growth inhibition: 8500 nM
Estimate against measurement, compound 4: 1.1-fold (0.03 log units) below, within the range that was stated.
By their numbers in this assay, from the lowest: compounds 2, 4, 1 and 3 (each within the scatter of the next, the first and the last beyond it).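

In this assay, replacing hydroxy, a single heavy atom carrying a hydrogen-bond donor, with nitro, which has 3 heavy atoms and no hydrogen-bond donor, gives a 1.5-fold higher number from compound 2 to compound 4 (0.19 log units; within the scatter). Measured against the bare ring, the same nitro gives a 1.0-fold lower number from compound 1 to compound 4 (0.01 log units; within the scatter), so hydrogen, hydroxy and nitro on this aromatic carbon, ortho to a large group, cannot be told apart by these numbers, and the hydrogen-bond donor of compound 2 is not needed to keep the number in this range. Nothing measured here bears on why these three groups read alike.

As far as these compounds go, whether an amine or a carboxylic acid on the same carbon would separate from hydrogen remains open, as does whether a nitro on another carbon of the ring would read the same. From the compounds shown here alone, all of these comparisons also come from a single cell line, so it remains unknown whether compound 2, compound 4 and compound 1 would stay this close in other cells.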